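A few compounds are considered here, and "the series" means these few. Any claim that something is new, unique, unknown or untested is made for them only; others in the source may bear on it.

The compounds share one core and were examined in a functional assay on Huh-7 cells (Homo sapiens) for cytotoxicity, read by CCK-8 assay, with a stated time of 72 h; a lower number here means a stronger inhibitor, a higher number a weaker inhibitor. Compound 1 `C=CCn1c(=O)/c(=C\c2cccc(C)c2)[nH]c(=O)/c1=C\c1ccccc1OC` gives 21400 nM in this assay, and this is the higher of the two numbers reported in the set. The nearest measured neighbour is compound 3 `COc1ccccc1/C=c1\c(=O)[nH]/c(=C/c2ccccc2Cl)c(=O)n1C`, which gives 300 nM in this assay, a gap that lies well beyond the scatter of the method; compound 3, however, differs from compound 1 in more than one place, so no single step can be read from that pair. Compound 2 `C=CCn1c(=O)/c(=C\c2ccc(Cl)c(Cl)c2)[nH]c(=O)/c1=C\c1ccccc1` is reported in this assay as "not active" (no number reported), without a number. Compound 4 `C=CCn1c(=O)/c(=C\c2cccc(Br)c2)[nH]c(=O)/c1=C\c1ccccc1OC` has not yet been measured. It differs from compound 1 by bromo in place of methyl on an aromatic carbon. Among the compounds with values here, no measured pair in this set changes only that position, so the size of the step rests on expectation alone. In this assay the expected step is a 1.4-fold lower number from compound 1 to compound 4 (0.15 log units; within the scatter), small and with no clear direction beyond the scatter. Compound 4 is therefore estimated at 15000 nM in this assay, within a range from 4000 nM to 60000 nM, with a real chance that it too is reported without a number.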

Compound 4, half-maximal inhibitory concentration: 2300 nM
Compound 4: the middle estimate sits 6.5-fold (0.81 log units) above what was measured; the measured number lies below the stated range.
By their numbers in this assay, from the lowest: compound 3; then compound 4; then compound 1.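

Within the data shown here, replacing 3-methylphenyl with 3-bromophenyl, with the rest of the molecule unchanged, gives in this assay a clear drop in the number (a 9.3-fold lower number from compound 1 to compound 4 (0.97 log units; beyond the scatter)), the first change at a single place that can be read in this set. The position on the aromatic ring is therefore not indifferent in this assay: one heavy atom exchanged for another, with no ring, hydrogen-bond donor, hydrogen-bond acceptor or net charge entering or leaving, moves the number beyond the scatter. Among these compounds, no measurement of any property of these two groups is available to bear on the result, and the data offer no account of the step.

The compounds shown leave open whether the lower number is particular to bromo or would also appear with another group at this position, such as a nitrile, an amine or a carboxylic acid. They also leave open whether the step would hold elsewhere on the shared core, as compound 3 differs from compound 4 in more than one place and cannot be set against it as a single change.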